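Ether chain to hydrocarbon chain on the shared core

The compounds below may be only part of what the source reports. "The series", "measured", "known", "first", "only" and "open" are said of these compounds alone.

Compound 1 `COc1cc(C(c2ccc(O)c(OC)c2)[C@@H](C)[C@@H](C)CF)ccc1O`, compound 2 `COC[C@@H](C(C)C)C(c1ccc(O)c(OC)c1)c1ccc(O)c(OC)c1` and compound 3 `COC[C@@H](C)[C@@H](C)C(c1ccc(O)c(OC)c1)c1ccc(O)c(OC)c1` share one core and differ only in the branched chain on a saturated chain carbon bound to two aromatic carbons. In a functional assay on HeLa cells (Homo sapiens) for cytotoxicity, read by WST assay, with a stated time of 48 h (on this read-out higher numbers stand for weaker inhibition and lower numbers for stronger inhibition), compound 1 gives 42000 nM and compound 2 gives 69000 nM. In this assay compound 3 gives only a limit, > 100000 nM. Compound 3 thus stands at the limit of the assay, without a number of its own, as recorded in the limit of > 100000 nM in this assay, at which 1 of the 3 values shown sits. The measured steps are: a 1.6-fold higher number from compound 1 to compound 2 (0.22 log units; within the scatter); an at least 2.3-fold higher number from compound 1 to compound 3 (0.37 log units; beyond the scatter); an at least 1.4-fold higher number from compound 2 to compound 3 (0.16 log units; that floor lies within the scatter).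

Compound 4 `COc1cc(C(c2ccc(O)c(OC)c2)[C@H](CC(C)C)C(C)C)ccc1O` is not yet measured. The change is 1-isopropyl-3-methylbutyl in place of 2-(methoxymethyl)-1-methylpropyl on a saturated chain carbon bound to two aromatic carbons. The single acceptor of the 2-(methoxymethyl)-1-methylpropyl group leaves and the all-carbon 1-isopropyl-3-methylbutyl group enters. Among the measured compounds shown here, the steps that touch compound 3 are the at-least-modest weakening from compound 1 and the step from compound 2 whose floor lies within the scatter; no measured step removes an acceptor from the chain, so no direction beyond the scatter can be drawn. Compound 4 is expected to stay close to the limit, with an estimate of 90000 nM and a range from 30000 nM to 300000 nM. The expected step is an at least 1.1-fold lower number from compound 3 to compound 4 (0.04 log units; that floor lies within the scatter).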

Compound 4, half-maximal inhibitory concentration: 8200 nM
For compound 4 the middle estimate is 11-fold (1.04 log units) above the measured one; measured number below the stated range.
By their numbers in this assay, from the lowest: compound 4; then compounds 1 and 2 (each within the scatter of the next). At a limit, above all of these: compound 3.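

The 1-isopropyl-3-methylbutyl group is the only chain shown on a saturated chain carbon bound to two aromatic carbons that lowers the number beyond the scatter in this assay, with a 5.1-fold lower number from compound 1 to compound 4 (0.71 log units; beyond the scatter) and an 8.4-fold lower number from compound 2 to compound 4 (0.93 log units; beyond the scatter). Compound 4, whose chain is all carbon, therefore stands as the strongest of the four compounds, whereas the steps among the chains with fluoromethyl or methoxymethyl ends showed only weakening or differences within the scatter. The third step, an at least 12-fold lower number from compound 3 to compound 4 (1.08 log units; beyond the scatter), gives a floor rather than a full size, and compound 3 holds only a limit, not a number: the limit of > 100000 nM in this assay, at which 1 of the 4 values shown sits.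

The new chain differs from the earlier ones in its branching and length as well as in its end group, and no pair shown changes one of these alone, so what drives the lower number remains open. How far the trend extends is also open: the compounds shown give no reading for a longer all-carbon chain, or for a chain ending in a hydroxymethyl group or an amine.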